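Methyl on Two Pyrimidine Cores and Growth Inhibition

The compounds below may be only part of what the source reports. "The series", "measured", "known", "first", "only" and "open" are said of these compounds alone.

Compound 1 `COc1cc(CC(O)(COCc2ccccc2)COCc2ccccc2)nc(OC)n1` was tested in a functional assay on MCF7 cells (Homo sapiens) for antiproliferative activity, read by MTT assay, with a stated time of 72 h; on this read-out higher numbers stand for weaker inhibition and lower numbers for stronger inhibition; here compound 1 reaches only the limit of the assay, > 100000 nM, and gives no number. Compound 2 `COc1nc(CC(O)(COCc2ccccc2)COCc2ccccc2)c(C)c(OC)n1` is the same molecule with a single change, (methyl in place of hydrogen on an aromatic carbon), and in this assay compound 2 gives 4200 nM. That change made an at least 23-fold lower number from compound 1 to compound 2 (1.37 log units; beyond the scatter).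

Compound 3 `O=c1cc(CC(O)COCc2ccccc2)[nH]c(=O)[nH]1` carries a different core; how its core differs from that of compound 1 is not broken down here. In this assay compound 3 also sits at the limit, > 100000 nM, and gives no number.

Compound 4 `Cc1c(CC(O)COCc2ccccc2)[nH]c(=O)[nH]c1=O` differs from compound 3 by methyl in place of hydrogen on an aromatic carbon. This is the same kind of change as in compound 2, but the surroundings differ: in compound 4 the methyl is ortho to a group of 1 heavy atom and para to a group of 1 heavy atom, whereas in compound 2 it is ortho to a methoxy group (2 heavy atoms) and para to a methoxy group (2 heavy atoms). Since compound 3 starts at the limit of > 100000 nM in this assay, at which 2 of the 3 values shown sit, the step from compound 3 to compound 4 is expected to be an at least 2.0-fold lower number from compound 3 to compound 4 (0.30 log units; that floor lies within the scatter), resting on the measured step of an at least 23-fold lower number from compound 1 to compound 2 (1.37 log units; beyond the scatter) in the other core. Compound 4 is therefore estimated at 50000 nM, with a real chance that only a limit is again reported.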

Compound 4, half-maximal inhibitory concentration: > 100000 nM
Compound 4: only a limit was reported; the forecaster's own chance of this, stated with the estimate: 45%; at least 2.0-fold (0.30 log units) between middle value and limit.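

Compound 3 and compound 4 are each reported only as a limit of the assay, not as a number, so the step between them cannot be read: the limit of > 100000 nM in this assay, at which 3 of the 4 values shown sit.

The compounds shown leave open whether methyl in place of hydrogen on an aromatic carbon lowers the number in the core of compound 3, as it does in the core of compound 1.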